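This account rests on a few compounds, and the source may have more. Where it says the series, first, only, none or still open, it means among the compounds named here.

Working notes on the series in a functional assay on MCF7 cells (Homo sapiens) for inhibition, read by MTT assay, with a stated time of 48 h; a lower number here means a stronger inhibitor, a higher number a weaker inhibitor. Compound 1 `COc1ccc(CN(c2cc(OC)c(OC)c(OC)c2)S(=O)(=O)c2ccc(C)cc2)cc1` gives 10100 nM in this assay. Compound 2 `COc1ccc(S(=O)(=O)N(Cc2nc3ccccc3[nH]2)c2cc(OC)c(OC)c(OC)c2)cc1OC` gives 47700 nM in this assay. Compound 3 `Cc1ccc(S(=O)(=O)N(Cc2nc3ccccc3[nH]2)c2ccc(F)cc2)cc1` returns no number in this assay but only a limit, > 50000 nM. That is where compound 3 stands among the values shown: the limit of > 50000 nM in this assay, at which 1 of the 3 values shown sits, so of the three measured compounds it is the one for which nothing more than the limit is in hand, and its distance to compound 1 and compound 2 cannot be stated as a step.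

Compound 4 `Cc1ccc(S(=O)(=O)N(Cc2nc3ccccc3[nH]2)c2ccc(Cl)cc2)cc1` is the next member and differs from compound 3 in one place: chloro in place of fluoro on an aromatic carbon. Going by the values given here, no pair of measured compounds differs by this change, so no measured step gives its size. Among the compounds with values here, nothing among the measured compounds speaks for a large movement from a change of one heavy atom at this place. With compound 3 at a limit, the expected step in this assay is none beyond the usual scatter, in either direction, and there is a fair chance that compound 4 is also reported only as a limit. The estimate for compound 4 is 50000 nM, between 20000 nM and 120000 nM, which means an expected step of a number no higher from compound 3 to compound 4 (the limit leaves the size open).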

Compound 4, half-maximal inhibitory concentration: 38300 nM
For compound 4 the middle estimate is 1.3-fold (0.12 log units) above the measured one, and the stated range covers the measured number.
By their numbers in this assay, from the lowest: compound 1; then compounds 4 and 2 (each within the scatter of the next). At a limit, above all of these: compound 3.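

In this assay, the 4-fluorophenyl to 4-chlorophenyl exchange gives the series its first step at this place, an at least 1.3-fold lower number from compound 3 to compound 4 (0.11 log units; that floor lies within the scatter), and this figure is a floor and not a size. Going by these compounds, compound 3 is held only at a limit, so the true distance to its neighbour stays unknown: the limit of > 50000 nM in this assay, at which 1 of the 4 values shown sits. Going by these compounds alone, what the earlier compounds did not show is that this aromatic carbon, para to a large group, can carry chloro in a compound with a readable number in this assay, although nothing here establishes a gain beyond the scatter.

What a primary amine, a carboxylic acid or a longer chain such as n-propyl would do in place of chloro on this carbon remains open, and with only two halogens shown, the position has no trend to read. Also open, on these data alone, is whether the exchange of fluoro for chloro would give a step of similar size in another member of the series, where neither partner stands at a limit.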